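Methyl on the amine nitrogen of compound 2

The source may report more compounds than this note shows. Statements on the series, on what has been measured and on what is new or still open speak of the compounds shown alone.

Measured in a functional assay on PC-3 cells (Homo sapiens) for cytotoxicity, read by MTT assay, with a stated time of 96 h; a higher number here means a weaker inhibitor, a lower number a stronger inhibitor:
Compound 1 (`CC[C@H](NC)C(=O)N[C@@H]1C(=O)N2[C@@H](CC[C@@H]1CN)CC[C@H]2C(=O)NC(c1ccccc1)c1ccccc1`) – 51700 nM
Compound 2 (`CC[C@H](N)C(=O)N[C@@H]1C(=O)N2[C@@H](CC[C@@H]1CCNC(=O)c1ccccc1)CC[C@H]2C(=O)NC(c1ccccc1)c1ccccc1`) – > 100000 nM (a limit of the assay, not a number)

Compound 2 has no numerical value in this assay, and the figure of compound 2 at > 100000 nM is a limit of the assay. Compound 3 (`CC[C@H](NC)C(=O)N[C@@H]1C(=O)N2[C@@H](CC[C@@H]1CCNC(=O)c1ccccc1)CC[C@H]2C(=O)NC(c1ccccc1)c1ccccc1`) has methyl in place of hydrogen on an amine nitrogen, turning the 1-aminopropyl group into 1-(methylamino)propyl. For the measured compounds named here, no step between measured compounds shows what this change does. Going by the values given here, the only number available is that of compound 1 at 51700 nM, and compound 1 also carries the 1-(methylamino)propyl group. On that basis, a modest move towards stronger inhibition is expected in this assay, though another limit would be no surprise. The expected step of an at least 2.2-fold lower number from compound 2 to compound 3 (0.34 log units; beyond the scatter) is only a rough estimate. Compound 3 is expected at 45000 nM, with an estimated range of 12000 nM to 100000 nM.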

Compound 3, half-maximal inhibitory concentration: > 100000 nM
Compound 3 gave a limit, no number; the forecaster's own chance of this, stated with the estimate: 40%; middle value at least 2.2-fold (0.34 log units) from the limit.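

In this assay the methyl on the amine nitrogen does not lift the series off its limit: compound 3 gives > 100000 nM, which is a limit of the assay and not a number. The step from compound 2 to compound 3 therefore cannot be read, because both compounds rest on the same limit: the limit of > 100000 nM in this assay, at which 2 of the 3 values shown sit. Benzamidomethyl in place of amino on a saturated chain carbon bound to a saturated ring carbon gives an at least 1.9-fold higher number from compound 1 to compound 3 (0.28 log units; that floor lies within the scatter), so the 1-(methylamino)propyl group alone does not bring a measured value with it.

On these data alone, what the methyl does in a pair where both partners give numbers remains open. So does the effect of an ethyl group on the same amine nitrogen, or of a free amine in place of the benzamide on compound 2.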